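Methyl to hydrogen on the ring of compound 3

The compounds below may be only part of what the source reports. "The series", "measured", "known", "first", "only" and "open" are said of these compounds alone.

The series is measured in a functional assay on HeLa cells (Homo sapiens), with a stated time of 3 days; on this read-out lower numbers stand for stronger inhibition and higher numbers for weaker inhibition. Compound 3, `Cc1cn([C@H]2OCC=CC2=O)c(=O)nc1O`, gives 34000 nM in this assay, the lowest of the two numbers recorded. Its nearest neighbour is compound 1, `C=C1C=CCO[C@@H]1n1cc(C)c(O)nc1=O`, which in this assay gives 339000 nM, a gap beyond the scatter. Compound 2, `C=C1[C@H](O)[C@H](O)CO[C@@H]1n1ccc(O)nc1=O`, reaches only a limit of this assay, >= 800000 nM, and so stands as the limit of >= 800000 nM in this assay, at which 1 of the 3 values shown sits, rather than as a number.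

Compound 4, `O=C1C=CCO[C@@H]1n1ccc(O)nc1=O`, has not yet been measured in this assay. It differs from compound 3 in one place: hydrogen in place of methyl on an aromatic carbon. Among the measured compounds shown here, no pair of measured compounds differs in this way alone, so the size of the step cannot be read from the data. Compound 2 lacks the methyl but also carries other changes and sits at a limit, so it gives no guide. The step from compound 3 to compound 4 is therefore expected to be modest, perhaps toward weaker inhibition, and the expected step is a 1.8-fold higher number from compound 3 to compound 4 (0.25 log units; within the scatter). Compound 4 is thus estimated to give 60000 nM in this assay, within a range from 15000 nM to 300000 nM.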

Compound 4, half-maximal inhibitory concentration: 42000 nM
Compound 4: middle estimate off by 1.4-fold (0.15 log units), on the high side, and the stated range covers the measured number.
By their numbers in this assay, from the lowest: compounds 3 and 4 (each within the scatter of the next); then compound 1. At a limit, above all of these: compound 2.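

In this assay, the exchange of methyl for hydrogen on this aromatic carbon, ortho to a hydroxy group, gives a 1.2-fold higher number from compound 3 to compound 4 (0.09 log units; within the scatter). Among the compounds shown here, this is the first pair that differs at this position alone, and it shows that the methyl is not needed to keep the number where it stands: with hydrogen there, the two compounds cannot be told apart in this assay. Nothing measured here bears on why the exchange leaves the number within the scatter.

As far as these compounds go, whether an ethyl chain, an amine or a fluorine on the same carbon would also leave the number within the scatter remains open. This single pair also cannot show whether the exchange would behave the same way on the core of compound 1.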